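The compounds below may be only part of what the source reports. "The series", "measured", "known", "first", "only" and "open" are said of these compounds alone.

Of the compounds shown here, three built on one shared core have been tested in a functional assay on HepG2 cells (Homo sapiens) for antiproliferative activity, read by MTT assay, with a stated time of 24 h; on this read-out lower numbers stand for stronger inhibition and higher numbers for weaker inhibition. Compound 1 `COc1ccc(C(=O)/C=C/c2ccc3ccccc3n2)c2c1C=CC(C)(C)O2` gives 4280 nM in this assay. Compound 2 `COc1ccc(C(=O)/C=C/c2cccc([N+](=O)[O-])c2)c2c1C=CC(C)(C)O2` gives 2830 nM in this assay. These two numbers sit within the usual scatter of one another, so compound 2 and compound 1 are not told apart by this assay. Compound 3 `COc1ccc(C(=O)/C=C/c2ccc(OC)c(OC)c2OC)c2c1C=CC(C)(C)O2` gives > 10000 nM in this assay, and this is a limit of the assay rather than a number. It is the limit of > 10000 nM in this assay, at which 1 of the 3 values shown sits, so for compound 3 only that boundary is known.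

The step of interest leads from compound 2 to compound 4 `COc1ccc(C(=O)/C=C/c2cccc(O)c2)c2c1C=CC(C)(C)O2`, a compound not yet measured. The two differ in one place: hydroxy in place of nitro on an aromatic carbon. Among the compounds with values here, no pair of measured compounds shows this same change, so no measured step tells how large its effect is. The nitro group of compound 2 is replaced by a smaller hydroxy group at the same carbon, and the rest of the molecule is untouched. Without a measured comparison, the expectation is for a step of modest size, or none beyond the scatter, and the direction is uncertain. Compound 4 is therefore estimated at 4000 nM in this assay, with a range from 1500 nM to 12000 nM, a step of a 1.4-fold higher number from compound 2 to compound 4 (0.15 log units; within the scatter) that is expected rather than known.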

Compound 4, half-maximal inhibitory concentration: > 10000 nM
Compound 4 ended at the assay's limit; the forecaster's own chance of this, stated with the estimate: 20%; middle value at least 2.5-fold (0.39 log units) from the limit.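

In this assay, the change from 3-nitrophenyl to 3-hydroxyphenyl gives an at least 3.5-fold higher number from compound 2 to compound 4 (0.54 log units; beyond the scatter). Within the data shown here, this shows that the carbon carrying these groups is not indifferent to what sits on it: with the rest of the molecule untouched, exchanging this one group is enough to produce a step beyond the scatter, something the earlier compounds, with no measured step among them, could not show. Compound 4 gives > 10000 nM, which is a limit of the assay rather than a number, and it shares that boundary with one other compound: the limit of > 10000 nM in this assay, at which 2 of the 4 values shown sit.

The compounds shown leave open whether this step comes from losing the nitro group or from gaining the hydroxy group, a question that an amine, a nitrile or a plain hydrogen at the same carbon could help to separate. Among these compounds, with only this one pair showing the change, it also remains open whether hydroxy in place of nitro would give a similar step at another carbon of the same aromatic ring.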